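Chloro to methyl on the aryl of compound 1

The source may hold more compounds than are shown below. What is called first, only, known or untested is meant among the compounds shown, and "the series" means these compounds.

Measured so far:
compound 1, `Nc1ccccc1NC(=O)c1ccc(CSC(=S)N2CCN(c3ccc(Cl)cc3)CC2)cc1`, 17.2%
compound 2, `Nc1ccccc1NC(=O)c1ccc(CSC(=S)N2CCCc3ccccc32)cc1`, 87.5%
compound 3, `CC1CCN(C(=S)SCc2ccc(C(=O)Nc3ccccc3N)cc2)CC1`, 81.9%

In a functional assay on MGC-803 cells (Homo sapiens) for antiproliferative activity, read by CCK-8 assay, with a stated time of 72 h, tested at 8 uM (on this read-out lower numbers stand for a weaker effect and higher numbers for a stronger effect at the one concentration tested), compound 1 gives the lowest of the three numbers; compound 3 and compound 2 both sit well above it, beyond the scatter, and the two of them lie within the scatter of each other, the change from one to the other being a number 5.6 percentage points lower from compound 2 to compound 3 (within the scatter).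

Compound 4, `Cc1ccc(N2CCN(C(=S)SCc3ccc(C(=O)Nc4ccccc4N)cc3)CC2)cc1`, is not yet measured. It differs from compound 1 by methyl in place of chloro on an aromatic carbon; cut one bond further out, the change reads 4-chlorophenyl to 4-methylphenyl.

Within the data shown here, no measured step touches this place. Among the measured compounds shown here, the only step in hand, a number 5.6 percentage points lower from compound 2 to compound 3 (within the scatter), exchanges the group on the thiocarbonyl carbon and lies within the scatter, so it says nothing about the aryl substituent. The expectation for compound 4 is therefore a step in this assay of a number 2.8 percentage points higher from compound 1 to compound 4 (within the scatter), none beyond the scatter.

Compound 4 is estimated to give 20%, with a range from 5% to 45%.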

Compound 4, a percentage reported as inhibition, at one concentration (the size of the read-out at that concentration, not a potency): 19.8%
Estimate against measurement, compound 4: 0.2 percentage points above, and the stated range covers the measured number.
By their numbers in this assay, from the lowest: compounds 1 and 4 (each within the scatter of the next); then compounds 3 and 2 (each within the scatter of the next).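

In this assay, the step of a number 2.6 percentage points higher from compound 1 to compound 4 (within the scatter) shows that methyl and chloro on this aromatic carbon cannot be told apart. The low number of compound 1 is therefore not specific to chloro: with 4-methylphenyl in place of 4-chlorophenyl, compound 4 gives 19.8%, while compound 3 gives 81.9%. No independent measurement accounts for this result or explains the low numbers of this pair.

Only these two small groups have been compared here, so an amine, a carboxylic acid or a methoxy group on this carbon could still behave differently. As far as these compounds go, it also remains open whether any substituent here can lift the number towards that of compound 3, or whether an unsubstituted phenyl would give a number like that of compound 1.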